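The compounds below may be only part of what the source reports. "The series", "measured", "known", "first", "only" and "open" are said of these compounds alone.

In a functional assay on CCRF-CEM cells (Homo sapiens) for antiproliferative activity, read by MTT assay, with a stated time of 48 h, tested at 12.5 uM (on this read-out lower numbers stand for a stronger effect and higher numbers for a weaker effect at the one concentration tested), compound 2 `OC(CCn1nc2c(Br)c(Br)c(Br)c(Br)c2n1)c1cccc(Cl)c1` gives 70%, the lower of the two numbers measured here. Compound 1 `OC(CCn1nc2c(Br)c(Br)c(Br)c(Br)c2n1)c1cccc(Br)c1` gives 118% in this assay. Within the data shown here, the only measured step is a number 48 percentage points lower from compound 1 to compound 2 (beyond the scatter), a large change from a single halogen swap. Compound 3 `OC(CCn1nc2c(Br)c(Br)c(Br)c(Br)c2n1)c1ccccc1` differs from compound 2 by hydrogen in place of chloro on an aromatic carbon. Among the measured compounds shown here, no measured step covers the loss of a halogen at this place, so the direction is uncertain, and a modest rise, a number 12 percentage points higher from compound 2 to compound 3 (beyond the scatter), is expected only as a cautious guess. Compound 3 is estimated at 82%, within 50% to 115%.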

Compound 3, a percentage reported as activity, at one concentration (the size of the read-out at that concentration, not a potency): 89%
Beside the measured number, compound 3's estimate is 7 percentage points below it; the range from low to high includes it.
By their numbers in this assay, from the lowest: compound 2; then compound 3; then compound 1.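

In this assay, going from 3-chlorophenyl to phenyl gives a number 19 percentage points higher from compound 2 to compound 3 (beyond the scatter), so chloro at this place goes with a stronger effect than hydrogen. Putting hydrogen in place of bromo gives a number 29 percentage points lower from compound 1 to compound 3 (beyond the scatter), so bromo goes with a weaker effect than hydrogen. The phenyl compound thus serves as a reference, and the two halogens fall on opposite sides of it rather than acting alike. Nothing available explains this split between chloro and bromo. Open, going by these compounds, is how fluoro, methoxy or an amine on this carbon would compare.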